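The source may report more compounds than this note shows. Statements on the series, on what has been measured and on what is new or still open speak of the compounds shown alone.

Working notes on the series. All three measured compounds carry the same core and differ only in the group on the aromatic nitrogen. Compound 1 `COC(=O)Cn1cc(CO[C@H]2CC(=O)[C@@H]3OC[C@H]2O3)nn1` gives 21300 nM in a functional assay on MDA-MB-231 cells (Homo sapiens) for cytotoxicity, read by MTT assay, with a stated time of 48 h; on this read-out higher numbers stand for weaker inhibition and lower numbers for stronger inhibition. Compound 2 `O=C1C[C@H](OCc2cn(-c3ccc(Cl)cc3)nn2)[C@H]2CO[C@@H]1O2` gives 26100 nM in this assay, and compound 3 `O=C1C[C@H](OCc2cn(-c3ccccc3Cl)nn2)[C@H]2CO[C@@H]1O2` gives 26400 nM. The three steps, a 1.2-fold higher number from compound 1 to compound 2 (0.09 log units; within the scatter), a 1.2-fold higher number from compound 1 to compound 3 (0.09 log units; within the scatter) and a 1.0-fold higher number from compound 2 to compound 3 (0.00 log units; within the scatter), all fall within the scatter, so compound 3 stands level with compound 1 and compound 2; none of the three can be called stronger or weaker than another.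

Compound 4 `O=C1C[C@H](OCc2cn(-c3ccccc3Br)nn2)[C@H]2CO[C@@H]1O2` differs from compound 3 by bromo in place of chloro on an aromatic carbon. Among the compounds with values here, no measured step exchanges one halogen for another. The step that comes closest is a 1.0-fold higher number from compound 2 to compound 3 (0.00 log units; within the scatter), which exchanged 4-chlorophenyl for 2-chlorophenyl without moving the number beyond the scatter. The swap of a chloro for a bromo is a smaller change than any step already seen, so no shift beyond the scatter is expected, and the step of a 1.0-fold lower number from compound 3 to compound 4 (0.01 log units; within the scatter) is the estimate. Compound 4 is therefore expected at 26000 nM, with a range from 13000 nM to 52000 nM.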

Compound 4, half-maximal inhibitory concentration: 22500 nM
The estimate for compound 4 lay 1.2-fold (0.06 log units) above the measured number; the range from low to high includes it.
By their numbers in this assay, from the lowest: compounds 1, 4, 2 and 3 (each within the scatter of the next).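

Within the data shown here, the first halogen exchange, bromo in place of chloro on an aromatic carbon ortho to a large group, gives in this assay a 1.2-fold lower number from compound 3 to compound 4 (0.07 log units; within the scatter) and so leaves the read-out within the scatter. The 2-bromophenyl group also stands level with the other two groups on the aromatic nitrogen, with a 1.2-fold lower number from compound 2 to compound 4 (0.06 log units; within the scatter) against 4-chlorophenyl and a 1.1-fold higher number from compound 1 to compound 4 (0.02 log units; within the scatter) against (methoxycarbonyl)methyl, so all four compounds now sit within the scatter of one another. Nothing beyond these numbers bears on the result.

On these data alone, whether a 4-bromophenyl group would stay level with these four compounds remains open. Also open, as far as these compounds go, is whether an amine or a carboxylic acid on the aromatic ring, or a longer chain on the aromatic nitrogen, would move the number beyond the scatter.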